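The compounds below may be only part of what the source reports. "The series", "measured", "known", "first", "only" and "open" are said of these compounds alone.

Measured so far:
compound 1 `O=C(/C=C/c1ccc(OCc2cn(Cc3ccc(F)cc3)nn2)cc1)c1ccc(Br)cc1` – 32%
compound 2 `O=C(/C=C/c1ccc(OCc2cn(Cc3cccc(Br)c3)nn2)cc1)c1ccc([N+](=O)[O-])cc1` – 21%
compound 3 `O=C(/C=C/c1ccc(OCc2cn(Cc3ccc(Br)cc3)nn2)cc1)c1ccc([N+](=O)[O-])cc1` – 17%

In a functional assay on MIA PaCa-2 cells (Homo sapiens) for inhibition, read by MTT assay, with a stated time of 48 h, tested at 10 uM (a higher number here means more inhibition of growth at the concentration tested, a lower number less inhibition of growth), compound 3 gives 17%, the lowest of the three numbers. The nearest number lies within the scatter, a number 4 percentage points lower from compound 2 to compound 3 (within the scatter); the furthest belongs to compound 1 with 32%, a gap beyond the scatter, but compound 1 differs from compound 3 in two places at once, so that gap cannot be assigned to either change alone.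

Compound 4 `O=C(/C=C/c1ccc(OCc2cn(Cc3ccc(F)cc3)nn2)cc1)c1ccc([N+](=O)[O-])cc1` is obtained from compound 3 by fluoro in place of bromo on an aromatic carbon, that is 4-bromobenzyl to 4-fluorobenzyl. Within the data shown here, no measured step isolates this exchange: the only single-place step, a number 4 percentage points lower from compound 2 to compound 3 (within the scatter), moves the bromo between positions of the same ring and stays within the scatter. Both nitro-bearing compounds, compound 2 and compound 3, sit at the low end whatever the halogen's position, so no step beyond the scatter is expected in this assay, a number 3 percentage points higher from compound 3 to compound 4 (within the scatter). Compound 4 is therefore estimated at 20%, with a range of 8% to 34%.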

Compound 4, percent growth inhibition at one concentration: 44%
Estimate against measurement, compound 4: 24 percentage points below; measured number above the stated range.
By their numbers in this assay, from the lowest: compounds 3 and 2 (each within the scatter of the next); then compound 1; then compound 4.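

In this assay the halogen on the benzyl group matters when the nitro is held: fluoro in place of bromo on an aromatic carbon, para to a large group, gives a number 27 percentage points higher from compound 3 to compound 4 (beyond the scatter) and 4-fluorophenyl in place of 3-bromophenyl gives a number 23 percentage points higher from compound 2 to compound 4 (beyond the scatter), so both bromo compounds lie beyond the scatter of the fluoro compound. With the 4-fluorobenzyl held, nitro in place of bromo gives a number 12 percentage points higher from compound 1 to compound 4 (beyond the scatter). No measurement shown here explains why the fluoro exchange moves the number this far.

As far as these compounds go, whether the exchange gives a step of similar size with bromo in place of the nitro stays open. So does whether a chloro, a methoxy or an amine in place of the fluoro would follow the fluoro or the bromo compounds.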